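A few compounds are considered here, and "the series" means these few. Any claim that something is new, unique, unknown or untested is made for them only; others in the source may bear on it.

Measured compounds:
- compound 1, `O=C(CSc1nnnn1-c1ccccc1)N/N=c1/scc(-c2ccc(Br)cc2)n1-c1ccccc1`: 24.3%
- compound 2, `Cn1cnnc1SCC(=O)N/N=c1/scc(-c2ccc(C#N)cc2)n1-c1ccccc1`: 55.2%
- compound 3, `Cn1cnnc1SCC(=O)N/N=c1/scc(-c2ccccc2)n1-c1ccccc1`: 38.6%

These three compounds were tested in a functional assay on C6 cells (Rattus norvegicus) for cytotoxicity, read by MTT assay, with a stated time of 24 h, tested at 100 ug/mL; a higher number here means a weaker effect of the compound at the concentration tested, a lower number a stronger effect. Compound 2 stands highest of the three numbers; the nearest is compound 3, which gives 38.6%, and the step from hydrogen in place of cyano is a number 16.6 percentage points lower from compound 2 to compound 3 (beyond the scatter). Furthest away is compound 1, which gives 24.3%.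

Compound 4, `N#Cc1ccc(-c2cs/c(=N/NC(=O)CSc3nnnn3-c3ccccc3)n2-c2ccccc2)cc1`, has not yet been measured in this assay. It differs from compound 2 in one place: 1-phenyl-1H-tetrazol-5-yl in place of 4-methyl-4H-1,2,4-triazol-3-yl on a sulfur. Within the data shown here, no measured step bears on this change directly. Among the measured compounds shown here, the only measured step, a number 16.6 percentage points lower from compound 2 to compound 3 (beyond the scatter), concerns a different place. For the measured compounds named here, compound 1 carries the same 1-phenyl-1H-tetrazol-5-yl group, but compound 1 and compound 3 differ in two places, so their values show only that the tetrazole-bearing compound has the lower number. The expected step in this assay is therefore uncertain, most likely downward. Compound 4 is expected to give 40%, within 20% to 62%. The expected step is a number 15.2 percentage points lower from compound 2 to compound 4 (beyond the scatter).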

Compound 4, a percentage reported as activity, at one concentration (the size of the read-out at that concentration, not a potency): 59.8%
Compound 4: middle estimate off by 19.8 percentage points, on the low side; low and high end bracket the measured number.
By their numbers in this assay, from the lowest: compound 1; then compound 3; then compounds 2 and 4 (each within the scatter of the next).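

In this assay, putting 1-phenyl-1H-tetrazol-5-yl in place of 4-methyl-4H-1,2,4-triazol-3-yl on the sulfur gives a number 4.6 percentage points higher from compound 2 to compound 4 (within the scatter), so at this position, with cyano on the aromatic carbon, the extra phenyl ring leaves no change that can be told from scatter. Compound 1 and compound 4 both carry the tetrazole. With that group kept, cyano in place of bromo gives a number 35.5 percentage points higher from compound 1 to compound 4 (beyond the scatter). This place on the aromatic ring, not the group on the sulfur, is what moves the read-out in these pairs, and removing cyano from the triazole series points the same way, with a number 16.6 percentage points lower from compound 2 to compound 3 (beyond the scatter).

Nothing given here explains why these steps are large or small. From the compounds shown here alone, it remains open whether the tetrazole and triazole also match when bromo replaces cyano, and whether a group without a ring on the sulfur, such as a methyl or a short chain ending in a carboxylic acid, would behave alike.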